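Anilino for benzylamino on the shared core

The source may report more compounds than this note shows. Statements on the series, on what has been measured and on what is new or still open speak of the compounds shown alone.

Three compounds of the series have numbers in a functional assay on MCF7 cells (Homo sapiens) for inhibition, read by CCK-8 assay, with a stated time of 48 h; a lower number here means a stronger inhibitor of growth, a higher number a weaker inhibitor of growth. Compound 1 `Cc1ccccc1Nc1nc(NCc2ccccc2)ncc1Cl` reaches only the limit of the assay, > 100000 nM, and no number beyond that limit is known for it; (the limit of > 100000 nM in this assay, at which 1 of the 3 values shown sits). Compound 2 `Cc1ccccc1Nc1nc(Nc2ccc(N3CCN(C)CC3)cc2)ncc1Cl` gives 20600 nM. Compound 3 `Cc1ccc(CNc2nc(Nc3ccc(N4CCN(C)CC4)cn3)ncc2Cl)cc1` gives 38100 nM, the highest of the two numbers on record, with compound 2 as its nearest neighbour at a gap that lies within the usual scatter, so no order between compound 2 and compound 3 is claimed.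

Compound 4 `CC(C)c1ccccc1Nc1nc(Nc2ccc(N3CCN(C)CC3)cn2)ncc1Cl` has not yet been measured in this assay. It differs from compound 3 in one place: 2-isopropylphenyl in place of 4-methylbenzyl on a nitrogen on an aromatic ring. Going by the values given here, no measured pair carries this same change, so its size is an expectation only. Among the compounds with values here, what the two known numbers show is that compound 2, with an anilino group on that nitrogen, gives 20600 nM, while compound 3 with a benzylamino group gives 38100 nM, a gap within the scatter.

For compound 4 the step of a 2.5-fold lower number from compound 3 to compound 4 (0.40 log units; beyond the scatter) is expected to be a modest move toward a lower number, not clearly beyond the scatter. Compound 4 is estimated at 15000 nM, within the range 4000 nM to 60000 nM.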

Compound 4, concentration for 50% growth inhibition: 4360 nM
Estimate against measurement, compound 4: 3.4-fold (0.54 log units) above; measured number inside the range.
By their numbers in this assay, from the lowest: compound 4; then compounds 2 and 3 (each within the scatter of the next). At a limit, above all of these: compound 1.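

At the nitrogen on an aromatic ring, compounds 3 and 4 form the only pair shown that differs in one place, and it gives this position its first readable step: in this assay, the change from 4-methylbenzyl to 2-isopropylphenyl gives an 8.7-fold lower number from compound 3 to compound 4 (0.94 log units; beyond the scatter). The position therefore responds to this change, although both groups contain one six-membered aromatic ring of carbon only and neither has a hydrogen-bond donor or acceptor, so those counts do not distinguish them. Nothing recorded for the series bears on why the number moves, and no cause can be assigned to the step.

Going by these compounds alone, with only this pair, the effect of going from a (4-methylbenzyl)amino to an anilino-type link cannot be separated from the effect of the isopropyl group, and the size of the step under any other part of the molecule remains unknown. Also open, as far as these compounds go, is how the number would respond to a group such as a tert-butyl, a longer chain, an amine or a carboxylic acid on the ring at this position.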